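Series notes: methoxy to cyano on the phenyl

The source may report more compounds than this note shows. Statements on the series, on what has been measured and on what is new or still open speak of the compounds shown alone.

In an assay on CHO cells for displacement of a labelled ligand from adenosine receptor A3 (Homo sapiens), read by scintillation counting, with a stated time of 3 h (a lower number here means a stronger inhibitor, a higher number a weaker inhibitor), the two measured compounds stand as follows:
compound 1 `Nc1nc(-c2ccccc2)nc2sc(-c3ccccc3)nc12`: 84 nM
compound 2 `COc1cccc(-c2nc(N)c3nc(-c4ccccc4)sc3n2)c1`: 35.6 nM

For the measured compounds named here, compound 2 holds the lower of the two numbers; the only measured step, a 2.4-fold lower number from compound 1 to compound 2 (0.37 log units; beyond the scatter), separates it from compound 1 and is modest. Compound 3 `N#Cc1cccc(-c2nc(N)c3nc(-c4ccccc4)sc3n2)c1` differs from compound 2 by cyano in place of methoxy on an aromatic carbon. Going by the values given here, no measured step bears directly on this exchange: the one known step concerns methoxy entering where hydrogen stood, not one acceptor-bearing group replaced by another of like size, as the tally shows. Among the compounds with values here, with only that modest step as background, the expected step for compound 3 is a 1.1-fold higher number from compound 2 to compound 3 (0.05 log units; within the scatter), small and of uncertain direction, possibly within the scatter. Compound 3 is therefore estimated at 40 nM in this assay, with a range from 15 nM to 110 nM.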

Compound 3, inhibition constant: 247 nM
For compound 3 the middle estimate is 6.2-fold (0.79 log units) below the measured one, and the stated range ends below it.
By their numbers in this assay, from the lowest: compound 2; then compound 1; then compound 3.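

At this place on the phenyl ring, meta to a large group, the read-out in this assay separates two groups that match in heavy-atom and hydrogen-bond acceptor counts: going from 3-methoxyphenyl to 3-cyanophenyl gives (a 6.9-fold higher number from compound 2 to compound 3 (0.84 log units; beyond the scatter)). Substitution here does not lower the number as such, since cyano in place of hydrogen runs opposite to the methoxy step (a 2.9-fold higher number from compound 1 to compound 3 (0.47 log units; beyond the scatter)). No measured evidence accompanying these values accounts for the difference between the two groups.

Still open, on these data alone, is how other groups at this place, such as an amine, a carboxylic acid or a longer chain like ethoxy, would stand against methoxy. Also open, as far as these compounds go, is whether the order of methoxy, hydrogen and cyano holds at other places on this ring or on the other phenyl ring.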